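This account rests on a few compounds, and the source may have more. Where it says the series, first, only, none or still open, it means among the compounds named here.

In an assay on cells for inhibition of Polyunsaturated fatty acid 5-lipoxygenase (Homo sapiens), read by HPLC, with a stated time of 15 min (on this read-out lower numbers stand for stronger inhibition and higher numbers for weaker inhibition), compound 3 `CCOC(=O)c1c(CSc2ccc(F)cc2F)n(C)c2ccc(O)cc12` gives 6800 nM, the highest of the three numbers recorded. Going by the values given here, compound 1 `CCOC(=O)c1c(CSc2ccc(OC)cc2)n(C)c2ccc(O)cc12` gives 3100 nM, and compound 2 `CCOC(=O)c1c(CSc2ccccc2C(F)(F)F)n(C)c2ccc(O)cc12` gives 1200 nM; the one directly comparable step, a 2.2-fold higher number from compound 1 to compound 3 (0.34 log units; beyond the scatter), shows that exchanging the aryl group on the sulfur can move the number by a modest amount. Compound 4 `CCOC(=O)c1c(CSc2c(C)cc(C)cc2C)n(C)c2ccc(O)cc12` carries 2,4,6-trimethylphenyl in place of 2,4-difluorophenyl on a sulfur. Among the compounds with values here, no measured pair tests a methyl-bearing aryl group here, so the direction rests only on the observation that each aryl exchange so far shifted this assay by a modest step. Compound 4 is therefore expected to come in near 3000 nM, within 1000 nM to 9000 nM, which would correspond to an estimated 2.3-fold lower number from compound 3 to compound 4 (0.36 log units; beyond the scatter).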

Compound 4, half-maximal inhibitory concentration: 230 nM
Compound 4: the middle estimate sits 13-fold (1.12 log units) above what was measured, outside the stated range (below it).
By their numbers in this assay, from the lowest: compound 4; then compound 2; then compound 1; then compound 3.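

The aryl group on the sulfur can move the number in this assay much further than the earlier exchange suggested: 2,4,6-trimethylphenyl gives a 30-fold lower number from compound 3 to compound 4 (1.47 log units; beyond the scatter) and a 13-fold lower number from compound 1 to compound 4 (1.13 log units; beyond the scatter), both large steps where the earlier one was modest. Nothing measured here accounts for this change.

Still open, from the compounds shown here alone, is how an unsubstituted phenyl, or an aryl ring carrying isopropyl groups, would read on this sulfur. Also open, going by these compounds, is whether the low number of compound 4 would hold if a carboxylic acid replaced the ethyl ester of the shared core.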